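A few compounds are considered here, and "the series" means these few. Any claim that something is new, unique, unknown or untested is made for them only; others in the source may bear on it.

Measured so far in an in vitro ADME assay on microsomes from liver (Mus musculus, strain CD1) for metabolic stability, read by HPLC, with a stated time of 4 h; a higher number here means faster removal of the compound, a lower number slower removal:

- compound 1 `CCOC(=O)c1c(-c2cccc(Cl)c2)[nH]c2cc(OC)ccc2c1=O` gives 16 mL.min-1.g-1
- compound 2 `CCOC(=O)c1c(-c2cccc(Oc3ccccc3)c2)[nH]c2cc(OC)c(F)cc2c1=O` gives 16 mL.min-1.g-1
- compound 3 `CCOC(=O)c1c(-c2cccc(Cl)c2)[nH]c2cc(OC)c(F)cc2c1=O` gives 4 mL.min-1.g-1

Of these three, compound 3 has the lowest number, so it is the most slowly removed. The next structure is compound 4 `CCOC(=O)c1c(-c2cc(F)cc(OC)c2)[nH]c2cc(OC)c(F)cc2c1=O`, where 3-fluoro-5-methoxyphenyl takes the place of the 3-chlorophenyl next to the ring nitrogen. The count of that change reads 3-fluoro-5-methoxyphenyl in place of 3-chlorophenyl on an aromatic carbon and shows that the incoming group brings one hydrogen-bond acceptor.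

Within the data shown here, two measured steps bear on this. The closer guide is the swap of phenoxy for chloro on the same phenyl ring, which gave a 4.0-fold lower number from compound 2 to compound 3 (0.60 log units; beyond the scatter) and shows that a change on this ring can move the number by a modest amount. The other is the fluoro added to the core, which gave a 4.0-fold lower number from compound 1 to compound 3 (0.60 log units; beyond the scatter) and bears less directly, since that fluoro stays in compound 4. Among the measured compounds shown here, no measured compound carries the new pair of groups, so the direction remains uncertain. With compound 3 at the bottom of the measured values, a modest rise seems more likely than a further fall. The expected change is a 2.3-fold higher number from compound 3 to compound 4 (0.35 log units; beyond the scatter) in this assay, somewhat smaller than the measured steps. For compound 4 the estimate is 9 mL.min-1.g-1, with an expected range from 3 mL.min-1.g-1 to 24 mL.min-1.g-1.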

Compound 4, intrinsic clearance in microsomes: 6.7 mL.min-1.g-1
Estimate against measurement, compound 4: 1.3-fold (0.13 log units) above, and the stated range covers the measured number.
By their numbers in this assay, from the lowest: compounds 3 and 4 (each within the scatter of the next); then compounds 1 and 2 (each within the scatter of the next).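

In this assay, 3-fluoro-5-methoxyphenyl in place of 3-chlorophenyl gives a 1.7-fold higher number from compound 3 to compound 4 (0.22 log units; within the scatter), so compound 3 and compound 4 cannot be told apart in how fast they are removed. The earlier compounds shown here showed that a change on this phenyl ring can matter, with phenoxy to chloro giving a 4.0-fold lower number from compound 2 to compound 3 (0.60 log units; beyond the scatter), and the new result adds that not every change there does: this larger group, which brings one hydrogen-bond acceptor, leaves the number within the scatter of the 3-chlorophenyl compound. Nothing measured here accounts for this outcome, or for the difference between the two changes on this ring.

From the compounds shown here alone, the fluoro and the methoxy enter together, so their separate contributions remain unknown, and they could be offsetting each other or could each have little effect. Going by these compounds, it also remains open how the number would respond to quite different groups on this phenyl ring, such as an amine or a carboxylic acid, or to an amide in place of the ethoxycarbonyl group on the shared core.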